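Chloro on the sulfonyl phenyl: a first estimate

This account rests on a few compounds, and the source may have more. Where it says the series, first, only, none or still open, it means among the compounds named here.

Measured so far:
compound 1 `COc1ccc(-n2cc(NC(=O)c3cccc(NS(=O)(=O)c4ccccc4)c3)cn2)cc1` – 76800 nM
compound 2 `COc1cccc(-n2cc(NC(=O)c3cccc(NS(=O)(=O)c4ccccc4)c3)cn2)c1` – 81100 nM

Within the data shown here, in a functional assay on A549 cells (Homo sapiens) for inhibition, read by MTT assay, with a stated time of 48 h (on this read-out lower numbers stand for stronger inhibition and higher numbers for weaker inhibition), compound 1 gives 76800 nM, the lowest of the two numbers so far, with compound 2 at 81100 nM as its nearest neighbour; the step of a 1.1-fold higher number from compound 1 to compound 2 (0.02 log units; within the scatter) lies within the scatter, so the two stand level. That step concerns the methoxyphenyl on the aromatic nitrogen and leaves the phenylsulfonyl untouched.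

Compound 3 `COc1ccc(-n2cc(NC(=O)c3cccc(NS(=O)(=O)c4ccc(Cl)cc4)c3)cn2)cc1` is the next entry. Against compound 1 it shows (chloro in place of hydrogen on an aromatic carbon), which cut one bond further out reads phenylsulfonyl to (4-chlorophenyl)sulfonyl. Among the measured compounds shown here, no measured step touches this part of the molecule, so nothing so far bears on it directly; the only measured step, elsewhere in the structure, was flat. For the measured compounds named here, with no precedent, the expected step of a 1.3-fold lower number from compound 1 to compound 3 (0.11 log units; within the scatter) in this assay is small and of uncertain direction, likely within the scatter. For compound 3 the estimate in this assay is 60000 nM, within a range from 20000 nM to 200000 nM, pending the measurement.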

Compound 3, half-maximal inhibitory concentration: 29700 nM
For compound 3 the middle estimate is 2.0-fold (0.31 log units) above the measured one; the measured number falls inside the stated range.
By their numbers in this assay, from the lowest: compound 3; then compounds 1 and 2 (each within the scatter of the next).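

In this assay the phenylsulfonyl end of the molecule proves sensitive to a single substitution: chloro in place of hydrogen on an aromatic carbon, para to a large group, gives a 2.6-fold lower number from compound 1 to compound 3 (0.41 log units; beyond the scatter), a modest step but the first in this series beyond the scatter. The only earlier step, from 4-methoxyphenyl to 3-methoxyphenyl on the aromatic nitrogen, was flat at a 1.1-fold higher number from compound 1 to compound 2 (0.02 log units; within the scatter), which leaves the (4-chlorophenyl)sulfonyl change as the only single change shown here that moves the number beyond the scatter. Nothing at hand explains why this change has the effect it has.

On these data alone, whether the step belongs to chloro specifically remains open, since fluoro, methyl, methoxy or an amine at the same place would each test how far it extends to other groups. Also open, as far as these compounds go, is whether the same chloro change would give a similar step on the 3-methoxyphenyl compound 2, which would show whether the two ends of the molecule act independently.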